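Trimming the Bromobenzyl Group Down to Methyl

The compounds below may be only part of what the source reports. "The series", "measured", "known", "first", "only" and "open" are said of these compounds alone.

Three imides built on one shared core have been measured in a functional assay on DU-145 cells (Homo sapiens) for inhibition, read by WST assay, with a stated time of 48 h; on this read-out lower numbers stand for stronger inhibition of growth and higher numbers for weaker inhibition of growth. Compound 1 `C=C(C)C(=O)N(Cc1ccc(Br)cc1)C(=O)/C=C/c1cc(OC)c(OC)c(OC)c1` gives 900 nM, the lowest number of the three and thus the strongest growth inhibitor shown, since both its steps to the others lie beyond the scatter. Compound 2 `C#CCN(C(=O)/C=C/c1cc(OC)c(OC)c(OC)c1)C(=O)C(=C)C` gives 2300 nM, and compound 3 `C=C(C)C(=O)N(Cc1cccc(Br)c1)C(=O)/C=C/c1cc(OC)c(OC)c(OC)c1` gives 5700 nM. The step of a 2.6-fold higher number from compound 1 to compound 2 (0.41 log units; beyond the scatter) and the step of a 6.3-fold higher number from compound 1 to compound 3 (0.80 log units; beyond the scatter) show that any change away from the 4-bromophenyl group of compound 1 so far weakened inhibition, though only modestly.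

Compound 4 `C=C(C)C(=O)N(C)C(=O)/C=C/c1cc(OC)c(OC)c(OC)c1` takes this further: hydrogen in place of 4-bromophenyl on a saturated chain carbon bound to an amide-type nitrogen. Read one bond further out, 4-bromobenzyl becomes methyl, so the group that distinguished compound 1 is removed entirely rather than exchanged. Both measured steps point the same way, so a rise in the number beyond the scatter is expected in this assay, probably larger than the loss seen on going to ethynyl. Compound 4 is therefore estimated at 3500 nM, with a likely range from 1200 nM to 12000 nM, a step of a 3.9-fold higher number from compound 1 to compound 4 (0.59 log units; beyond the scatter) expected.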

Compound 4, concentration for 50% growth inhibition: 5600 nM
Estimate against measurement, compound 4: 1.6-fold (0.20 log units) below; measured number inside the range.
By their numbers in this assay, from the lowest: compound 1; then compound 2; then compounds 4 and 3 (each within the scatter of the next).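

In this assay, cutting the 4-bromobenzyl group down to methyl gives a clear loss of growth inhibition (a 6.2-fold higher number from compound 1 to compound 4 (0.79 log units; beyond the scatter)). The 3-bromobenzyl group shows no edge over plain methyl (a 1.0-fold lower number from compound 3 to compound 4 (0.01 log units; within the scatter)), so among these compounds a bromophenyl group helps only with the bromine placed as in 4-bromophenyl. The ethynyl group keeps a modest edge over methyl (a 2.4-fold higher number from compound 2 to compound 4 (0.39 log units; beyond the scatter)), which shows that an aromatic ring is not needed for some gain at this position on a saturated chain carbon bound to an amide-type nitrogen.

No evidence at hand explains these differences. From the compounds shown here alone, it also remains open whether a 4-chlorobenzyl group, a 4-methoxybenzyl group or a longer chain such as n-butyl would match the 4-bromobenzyl group of compound 1.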